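The source may hold more compounds than are shown below. What is called first, only, known or untested is meant among the compounds shown, and "the series" means these compounds.

Values so far in a functional assay on HeLa cells (Homo sapiens) for antiproliferative activity, read by sulforhodamine B assay; a lower number here means a stronger inhibitor of growth, a higher number a weaker inhibitor of growth:
- compound 1 `CCC[C@@H]1O[C@H](COCc2ccccc2)[C@@H](OCc2ccccc2)[C@H](OCc2ccccc2)[C@@H]1O`: 23300 nM
- compound 2 `CCCCOC[C@H]1O[C@@H](CCC)[C@H](O)[C@@H](OCCCC)C1OCCCC`: > 50000 nM (a limit)
- compound 3 `CCCC[C@@H]1O[C@H](COCc2ccccc2)[C@@H](OCc2ccccc2)[C@H](OCc2ccccc2)[C@H]1O`: > 50000 nM (a limit)

Compound 3 has no number, only the limit > 50000 nM. Compound 2 likewise gives only a limit. The series therefore sits mostly at the end of the measurable range: the limit of > 50000 nM in this assay, at which 2 of the 3 values shown sit. For the measured compounds named here, compound 1 is the only one with a number, 23300 nM.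

Compound 4 `O[C@@H]1[C@@H](OCc2ccccc2)[C@H](OCc2ccccc2)[C@@H](COCc2ccccc2)O[C@H]1c1ccccc1` keeps the rest of compound 3 and carries phenyl in place of butyl on a saturated ring carbon, next to the ring oxygen and next to the ring atom that bears a hydroxy group: phenyl in place of butyl on a saturated ring carbon.

Going by the values given here, no measured pair differs in one place, so no measured step sizes this change in this assay. The expectation is a small gain at most, or no change that can be read, with a real chance that compound 4 also ends at the limit. Among the compounds with values here, the only guide is compound 1 at 23300 nM, which shows that a number can be obtained from a close relative.

The expected step is an at least 1.4-fold lower number from compound 3 to compound 4 (0.15 log units; that floor lies within the scatter).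

For compound 4 the estimated value is 35000 nM, with an expected range from 12000 nM to 50000 nM.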

Compound 4, concentration for 50% growth inhibition: > 50000 nM
Compound 4: a limit, no number; the forecaster's own chance of this, stated with the estimate: 55%; middle value at least 1.4-fold (0.15 log units) from the limit.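

Compound 3 and compound 4 both end at a limit, not a number, in this assay, so no step can be read between them: the limit of > 50000 nM in this assay, at which 3 of the 4 values shown sit.

The compounds shown leave open whether phenyl in place of butyl on a saturated ring carbon changes growth inhibition at all.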